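Methyl for Chloro on the Benzyl Ring

The source may hold more compounds than are shown below. What is called first, only, known or untested is meant among the compounds shown, and "the series" means these compounds.

Measured so far, in an assay on Midbrain with Type-2 angiotensin II receptor (Rattus norvegicus) as the target; on this read-out higher numbers stand for weaker inhibition and lower numbers for stronger inhibition:
- compound 1, `CCCc1nc2c(C)ccnc2n1Cc1ccc(OC(C(=O)O)c2ccccc2)cc1`, gives 3400 nM
- compound 2, `CCc1nc2c(C)cc(C)nc2n1Cc1ccc(OC(C(=O)O)c2ccccc2Cl)cc1`, gives 15000 nM
- compound 3, `CCc1nc2c(C)cc(C)nc2n1Cc1ccc(OC(C(=O)O)c2ccccc2)c(Cl)c1`, gives 720 nM

Compound 3 has the lowest number of the three, and its gaps to compound 1 and to compound 2 both lie beyond the usual scatter, so it is the strongest inhibitor of this small set in this assay. The next compound keeps the core of compound 3 and changes only one substituent: compound 4, `CCc1nc2c(C)cc(C)nc2n1Cc1ccc(OC(C(=O)O)c2ccccc2)c(C)c1`, differs from compound 3 by methyl in place of chloro on an aromatic carbon. Chloro and methyl are both single heavy atoms without donors, acceptors or charge, and no measured pair here shows what such a swap does on this ring. The expected step from compound 3 to compound 4 is therefore small, a 1.5-fold higher number from compound 3 to compound 4 (0.18 log units; within the scatter), near or only slightly beyond the scatter, with a modest weakening judged somewhat more likely than a gain. For compound 4 in this assay the estimate is 1100 nM, with a range from 350 nM to 3500 nM.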

Compound 4, half-maximal inhibitory concentration: 940 nM
The estimate for compound 4 lay 1.2-fold (0.07 log units) above the measured number, and the stated range covers the measured number.
By their numbers in this assay, from the lowest: compounds 3 and 4 (each within the scatter of the next); then compound 1; then compound 2.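

For the compounds shown here, compounds 3 and 4 form the first measured pair that differs only at this place, an aromatic carbon ortho to a large group and meta to a large group. In this assay, putting methyl in place of chloro gives a 1.3-fold higher number from compound 3 to compound 4 (0.12 log units; within the scatter), so this pair shows no measurable difference between the two groups at this place. No available measurement explains why the two groups read alike.

Going by these compounds alone, this single pair covers only two groups of one heavy atom each, so it cannot show how sensitive the place is to larger or very different changes. As far as these compounds go, whether a methoxy group, an amine, a carboxylic acid or a longer chain at this place would stay within the scatter of compound 3 remains open.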